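The source may report more compounds than this note shows. Statements on the series, on what has been measured and on what is new or still open speak of the compounds shown alone.

Measured in a functional assay on U-251 cells (Homo sapiens) for inhibition, read by MTT assay, with a stated time of 2 days; a higher number here means a weaker inhibitor of growth, a lower number a stronger inhibitor of growth:
Compound 1 `Nc1ccccc1NC(=O)CCCNCC(=O)Nc1cccc(Cl)c1`: 19500 nM
Compound 2 `Nc1ccccc1NC(=O)CCCNCC(=O)Nc1ccc(Cl)cc1`: 11400 nM
Compound 3 `Nc1ccccc1NC(=O)CCCNCC(=O)Nc1cccc([N+](=O)[O-])c1`: 15000 nM

Compound 3 cannot be told apart from the other two: a 1.3-fold lower number from compound 1 to compound 3 (0.11 log units; within the scatter) and a 1.3-fold higher number from compound 2 to compound 3 (0.12 log units; within the scatter) both lie within the scatter. Compound 4 `Nc1ccccc1NC(=O)CCCNCC(=O)Nc1cc(Cl)ccc1Cl` keeps the shared core, but 2,5-dichlorophenyl stands in place of 3-nitrophenyl on the amide-type nitrogen (2,5-dichlorophenyl in place of 3-nitrophenyl on an amide-type nitrogen). Those two steps bear on this change, since they exchange nitro and chloro, as does a 1.7-fold lower number from compound 1 to compound 2 (0.23 log units; within the scatter), which compares two chlorophenyl groups and also lies within the scatter. Going by the values given here, no measured compound carries two chlorines, so that feature remains untested. No step beyond the scatter is therefore expected in this assay. The expected step is a 1.3-fold lower number from compound 3 to compound 4 (0.10 log units; within the scatter). For compound 4 the estimated value is 12000 nM, with an expected range from 6000 nM to 24000 nM.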

Compound 4, concentration for 50% growth inhibition: 44000 nM
Compound 4: the middle estimate sits 3.7-fold (0.56 log units) below what was measured; measured number above the stated range.
By their numbers in this assay, from the lowest: compounds 2, 3 and 1 (each within the scatter of the next); then compound 4.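

In this assay the 2,5-dichlorophenyl group gives the weakest growth inhibitor of the four, with a 2.9-fold higher number from compound 3 to compound 4 (0.47 log units; beyond the scatter) and a 3.9-fold higher number from compound 2 to compound 4 (0.59 log units; beyond the scatter) and also a 2.3-fold higher number from compound 1 to compound 4 (0.35 log units; beyond the scatter) as modest steps beyond the scatter. Exchanges of single groups on the amide-type nitrogen had shown no measurable effect, so this place does respond once the phenyl group carries a second chlorine. Nothing measured here explains the loss of growth inhibition.

From the compounds shown here alone, whether the number of chlorines or their placement matters remains open. So does how a phenyl group carrying a methoxy group or an amine would behave here.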